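Replacing the nitrile chain on the amide of compound 2

The source may hold more compounds than are shown below. What is called first, only, known or untested is meant among the compounds shown, and "the series" means these compounds.

For the measured compounds named here, compound 2 `C=CCN(C)C(=O)c1ccc(C(CC)(CC)c2ccc(OCC(O)C(C)(C)C)c(C)c2)n1CC` gives 3950 nM in an assay on HL-60 cells for agonist activity at vitamin D3 receptor (Homo sapiens), read by microscopy, with a stated time of 96 h (a higher number here means that more compound is needed for the effect, a lower number that less compound is needed), the higher of the two numbers measured so far. Compound 1 `CCn1c(C(=O)N(C)CCC#N)ccc1C(CC)(CC)c1ccc(OCC(O)C(C)(C)C)c(C)c1` gives 1960 nM in this assay, and the step of a 2.0-fold higher number from compound 1 to compound 2 (0.30 log units; within the scatter) lies within the scatter. Compound 3 `CCn1c(C(=O)N(CCC#N)CCC#N)ccc1C(CC)(CC)c1ccc(OCC(O)C(C)(C)C)c(C)c1` is unmeasured; it differs from compound 2 by a group of 9 heavy atoms (6 carbon, 3 nitrogen; no ring) in place of a group of 5 heavy atoms (4 carbon, 1 nitrogen; no ring), on a carbonyl carbon. Going by the values given here, the only step that bears on this change is the one from compound 1 to compound 2, which stayed within the scatter, so no shift beyond the scatter is expected for compound 3, with a 1.4-fold lower number from compound 2 to compound 3 (0.15 log units; within the scatter). Compound 3 is estimated at 2800 nM, between 900 nM and 9000 nM.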

Compound 3, half-maximal effective concentration: 97 nM
The estimate for compound 3 lay 29-fold (1.46 log units) above the measured number; the measured number lies below the stated range.
By their numbers in this assay, from the lowest: compound 3; then compounds 1 and 2 (each within the scatter of the next).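

The amide substituent on the carbonyl carbon proves able to move this number well beyond the scatter, which the earlier pair did not show. Cyanomethyl in place of hydrogen on the saturated chain carbon bound to the amide-type nitrogen gives the first large change (a 20-fold lower number from compound 1 to compound 3 (1.31 log units; beyond the scatter)), and the whole group exchange gives a similar one (a 41-fold lower number from compound 2 to compound 3 (1.61 log units; beyond the scatter)). Nothing at hand explains either step.

Open, going by these compounds, is whether the second nitrile itself matters or any chain of that length would serve. A longer chain, an amine or a carboxylic acid at the end of that chain would separate these readings.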